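Swapping the aryl ring on the shared core of compound 1

A few compounds are considered here, and "the series" means these few. Any claim that something is new, unique, unknown or untested is made for them only; others in the source may bear on it.

Compound 1 `COc1cc(C2=NN(C(C)=O)C(c3cccc(F)c3)O2)cc(OC)c1OC`: 37.7%
Compound 2 `COc1cc(C(=O)N/N=C/c2cccc(F)c2)cc(OC)c1OC`: 44.8%

Both compounds were tested in a functional assay on BGC-823 cells (Homo sapiens) for antiproliferative activity, read by MTT assay, tested at 5 uM; on this read-out lower numbers stand for a weaker effect and higher numbers for a stronger effect at the one concentration tested. Compound 1 gives 37.7% there, the lower of the two numbers, and compound 2 gives 44.8%; the gap between them lies within the scatter, so the two values cannot be told apart.

Compound 3 `COc1cc(C2=NN(C(C)=O)C(c3ccc(C(F)(F)F)cc3)O2)cc(OC)c1OC` has not been measured. It differs from compound 1 in one place: 4-(trifluoromethyl)phenyl in place of 3-fluorophenyl on a saturated ring carbon. The change keeps the shared core and the acetyl group and exchanges only the aryl ring on the saturated ring carbon.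

Going by the values given here, no measured pair shows what such a swap does here, so there is no step to lean on. The expected change from compound 1 to compound 3 in this assay is small, a number 2.3 percentage points higher from compound 1 to compound 3 (within the scatter), likely no further than the scatter in either direction. Compound 3 is therefore estimated at 40%, with a range from 24% to 58%.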

Compound 3, a percentage reported as inhibition, at one concentration (the size of the read-out at that concentration, not a potency): 3.4%
Estimate against measurement, compound 3: 36.6 percentage points above, and the stated range ends above it.
By their numbers in this assay, from the lowest: compound 3; then compounds 1 and 2 (each within the scatter of the next).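

Exchanging the aryl ring on the saturated ring carbon is not a neutral change: in this assay, putting 4-(trifluoromethyl)phenyl in place of 3-fluorophenyl gives a number 34.3 percentage points lower from compound 1 to compound 3 (beyond the scatter), a large step. The shared core and the acetyl group stay the same, so this one position alone can separate a compound with a clear effect at the tested concentration from one with very little, as compound 3 gives only 3.4% there. Nothing in the available data explains why the number falls so far.

The swap alters both the group on the aryl ring and where it sits, and these compounds cannot pull those two changes apart. From the compounds shown here alone, whether a plain phenyl ring, or one carrying a methoxy group or an amine, would keep the effect or lose it remains open.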